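The source may hold more compounds than are shown below. What is called first, only, known or untested is meant among the compounds shown, and "the series" means these compounds.

Measured so far:
compound 1 `CC(=O)c1ccc(NC(=O)/C=C/C(=O)N2C/C(=C\c3ccc([N+](=O)[O-])cc3)C(=O)/C(=C/c3ccc([N+](=O)[O-])cc3)C2)cc1` — 390 nM in a functional assay on Molt4/C8 cells (Homo sapiens) for cytotoxicity; a lower number here means a stronger inhibitor, a higher number a weaker inhibitor
compound 2 `Cc1ccc(NC(=O)/C=C/C(=O)N2C/C(=C\c3ccc([N+](=O)[O-])cc3)C(=O)/C(=C/c3ccc([N+](=O)[O-])cc3)C2)cc1C` — 660 nM in this assay

For the measured compounds named here, compound 2 gives the higher of the two numbers, its only neighbour being compound 1, with the step of a 1.7-fold higher number from compound 1 to compound 2 (0.23 log units; within the scatter) lying within the scatter. The next step goes from compound 2 to compound 3 `Cc1cccc(C)c1NC(=O)/C=C/C(=O)N1C/C(=C\c2ccc([N+](=O)[O-])cc2)C(=O)/C(=C/c2ccc([N+](=O)[O-])cc2)C1`, which differs by 2,6-dimethylphenyl in place of 3,4-dimethylphenyl on an amide-type nitrogen. Going by the values given here, only the step from compound 1 to compound 2 concerns the same amide-type nitrogen, and it stayed within the scatter. Among the compounds with values here, no measured step tells how moving the two methyl groups on that ring matters, so no step beyond the scatter is expected in this assay, in either direction, as a 1.1-fold higher number from compound 2 to compound 3 (0.03 log units; within the scatter). Compound 3 is therefore estimated at 700 nM, with a range from 250 nM to 2000 nM.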

Compound 3, half-maximal inhibitory concentration: 210 nM
Compound 3: the middle estimate sits 3.3-fold (0.52 log units) above what was measured; measured number outside the range, below it.
By their numbers in this assay, from the lowest: compounds 3, 1 and 2 (each within the scatter of the next, the first and the last beyond it).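

In this assay the arrangement of the two methyl groups on the phenyl at the amide-type nitrogen matters, since the atoms stay the same and the change gives a 3.1-fold lower number from compound 2 to compound 3 (0.50 log units; beyond the scatter) as a modest step. The exchange of 4-acetylphenyl for 2,6-dimethylphenyl gives a 1.9-fold lower number from compound 1 to compound 3 (0.27 log units; within the scatter) and does not separate those two groups. Nothing measured here accounts for the difference between the two dimethylphenyl groups.

Open, going by these compounds, is how a single methyl, a methoxy group or an amine on that phenyl would compare. Also open, on these data alone, is whether the 2,6-dimethylphenyl result carries over to larger groups such as 2,6-diethylphenyl.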